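A few compounds are considered here, and "the series" means these few. Any claim that something is new, unique, unknown or untested is made for them only; others in the source may bear on it.

Compound 1 `COc1ccccc1CNc1ncnc2c1ncn2C1CCCCO1` and compound 2 `COc1ccc(OC)c(CNc2ncnc3c2ncn3C2CCCCO2)c1` share one core and differ by methoxy in place of hydrogen on an aromatic carbon. In an ADME assay on BJ cells (Homo sapiens) for cytotoxicity, read by MTT assay, with a stated time of 72 h (on this read-out lower numbers stand for stronger inhibition and higher numbers for weaker inhibition), compound 1 gives > 100000 nM, which is a limit of the assay. Compound 2 gives > 100000 nM in this assay, again a limit. Hence a step that the two limits leave unreadable from compound 1 to compound 2. Compound 3 `COc1ccc(CNc2ncnc3c2ncn3C2CCCO2)cc1` carries another core; the difference between the two cores is not broken down here. Compound 3 gives > 100000 nM in this assay, also a limit. Compound 4 `COc1ccc(CNc2ncnc3c2ncn3C2CCCO2)cc1OC` has not been measured and differs from compound 3 by methoxy in place of hydrogen on an aromatic carbon, the same kind of change, though here the entering methoxy sits ortho to a methoxy group and meta to a large group, whereas in the earlier case it sat meta to a large group and para to a methoxy group. The step from compound 3 to compound 4 is expected to be a step that the limit leaves unreadable from compound 3 to compound 4. This expectation rests on a step that the two limits leave unreadable from compound 1 to compound 2 and on (the limit of > 100000 nM in this assay, at which 3 of the 3 values shown sit). Compound 4 is expected to give 150000 nM.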

Compound 4, half-maximal inhibitory concentration: > 100000 nM
Compound 4 gave a limit, no number (the forecaster's own chance of this, stated with the estimate: 85%); the middle value lies beyond the limit too.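

Going by these compounds alone, compound 3 and compound 4 both sit at a limit in this assay, so no step between them can be read. The compounds shown leave open whether adding a methoxy changes the read-out at all, since every value is a limit: the limit of > 100000 nM in this assay, at which 4 of the 4 values shown sit.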